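The source may report more compounds than this note shows. Statements on the series, on what has been measured and on what is new or still open speak of the compounds shown alone.

Among the measured compounds shown here, compound 1 `N#Cc1ccc(OCC2CCN(CCCF)CC2)cc1` is one of three compounds measured in an assay for binding affinity to Sigma non-opioid intracellular receptor 1 (Rattus norvegicus); on this read-out higher numbers stand for weaker inhibition and lower numbers for stronger inhibition. Compound 1 gives 4.3 nM, the second highest of the three numbers; compound 2 `FCCCN1CCC(COc2ccc(Br)cc2)CC1` gives 0.38 nM, and compound 3 `N#Cc1ccccc1CN1CCC(COc2ccc(I)cc2)CC1` gives 10.5 nM. For the measured compounds named here, the one single-point step known is an 11-fold lower number from compound 1 to compound 2 (1.05 log units; beyond the scatter), a change on the aromatic ring, not on the ring nitrogen. Compound 4 `N#Cc1ccc(OCC2CCN(Cc3ccc(F)cc3)CC2)cc1` differs from compound 1 at that nitrogen: 4-fluorophenyl in place of 2-fluoroethyl on a saturated chain carbon bound to an amine nitrogen in a ring. Going by the values given here, no measured step covers this kind of change directly. Compound 2 and compound 3 carry different groups on both the nitrogen and the aromatic ring, so their values alone cannot isolate the effect. On this thin basis a modest step of a 1.9-fold higher number from compound 1 to compound 4 (0.27 log units; within the scatter) toward a higher number is expected, and compound 4 is estimated at 8 nM, within 2 nM to 30 nM.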

Compound 4, inhibition constant in the Sigma non-opioid intracellular receptor 1 assay: 0.76 nM
Estimate against measurement, compound 4: 11-fold (1.02 log units) above; measured number outside the range, below it.
By their numbers in the Sigma non-opioid intracellular receptor 1 assay, from the lowest: compounds 2 and 4 (each within the scatter of the next); then compound 1; then compound 3.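

At this position, on a saturated chain carbon bound to an amine nitrogen in a ring, swapping 2-fluoroethyl for 4-fluorophenyl gives in the Sigma non-opioid intracellular receptor 1 assay a 5.7-fold lower number from compound 1 to compound 4 (0.75 log units; beyond the scatter), with compound 1 at 4.3 nM and compound 4 at 0.76 nM, the first measured sign that an aromatic ring is tolerated here and goes with stronger inhibition. In a physicochemical assay for lipophilicity (a lower number here means a more polar compound, a higher number a more lipophilic compound), the same change gives a number 0.29 log units higher from compound 1 to compound 4 (within the scatter), with compound 1 at 2.93 and compound 4 at 3.22. Nothing available explains the step in binding.

Whether the fluorine on the new ring matters stays open, since plain benzyl does not appear among these compounds. From the compounds shown here alone, a longer chain ending in a phenyl ring on the same nitrogen also remains untested here.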